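Amide to amine on the coumarin side chain

The source may hold more compounds than are shown below. What is called first, only, known or untested is meant among the compounds shown, and "the series" means these compounds.

Measured so far:
compound 1 `NC(=O)[C@@H]1CCCN1Cc1cc(=O)oc2cc(OCc3ccccc3)ccc12` – 380 nM
compound 2 `CN(C)C(=O)Cc1cc(=O)oc2cc(OCc3ccccc3)ccc12` – 400 nM

Of the compounds shown here, two share one core and have been measured in an assay for inhibition of Amine oxidase [flavin-containing] B (Rattus norvegicus); a lower number here means a stronger inhibitor, a higher number a weaker inhibitor. Compound 1 `NC(=O)[C@@H]1CCCN1Cc1cc(=O)oc2cc(OCc3ccccc3)ccc12` gives 380 nM; compound 2 `CN(C)C(=O)Cc1cc(=O)oc2cc(OCc3ccccc3)ccc12` gives 400 nM. Within the data shown here, compound 2 thus holds the higher of the two numbers, yet the one measured step, a 1.1-fold higher number from compound 1 to compound 2 (0.02 log units; within the scatter), places it within the scatter of compound 1, so no order between them can be read.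

Compound 3 `CN(C)Cc1cc(=O)oc2cc(OCc3ccccc3)ccc12` has not yet been measured. It differs from compound 2 by dimethylamino in place of dimethylcarbamoyl on a saturated chain carbon bound to an aromatic carbon. Among the measured compounds shown here, no measured step concerns this change; the only step known, a 1.1-fold higher number from compound 1 to compound 2 (0.02 log units; within the scatter), exchanged one carbamoyl group for another and left the number where it was. For the measured compounds named here, the loss of the carbonyl is therefore a move into unknown ground, and the account offers no step of comparable kind.

On that basis compound 3 is expected to land near compound 2, with a wide range: its estimate in this assay is 600 nM, between 150 nM and 2500 nM, which means an expected step of a 1.5-fold higher number from compound 2 to compound 3 (0.18 log units; within the scatter).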

Compound 3, half-maximal inhibitory concentration: 1800 nM
Estimate against measurement, compound 3: 3.0-fold (0.48 log units) below; the measured number falls inside the stated range.
By their numbers in this assay, from the lowest: compounds 1 and 2 (each within the scatter of the next); then compound 3.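

In this assay, among these compounds, the side chain is no longer indifferent to what it carries: dimethylamino in place of dimethylcarbamoyl on a saturated chain carbon bound to an aromatic carbon gives a 4.5-fold higher number from compound 2 to compound 3 (0.65 log units; beyond the scatter) and is the first change to lie beyond the scatter. The exchange for 2-carbamoylpyrrolidin-1-yl reads the same way, with a 4.7-fold higher number from compound 1 to compound 3 (0.68 log units; beyond the scatter) on record, so among these three compounds the two groups holding a carbamoyl unit stay within the scatter of each other and the one group without it stands apart, even though 2-carbamoylpyrrolidin-1-yl, like dimethylamino, is joined to the chain carbon through its nitrogen. Nothing in the data on hand explains why the number moves with this change.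

Among the compounds shown here, with only three compounds, the pattern rests on a single group lacking the carbamoyl unit, and no compound here goes against it. A plain pyrrolidin-1-yl group on the same carbon would separate the effect of the ring from that of the carbamoyl unit, while a carboxylic acid or a longer chain ending in dimethylamino remains an open case at this position.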